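Swapping the Aryl Amino Group for Fluorine: an Expectation

A few compounds are considered here, and "the series" means these few. Any claim that something is new, unique, unknown or untested is made for them only; others in the source may bear on it.

Measured compounds:
compound 1, `CCCc1cc(N)c2cc(NC(=O)/C=C/c3ccc(C(C)(C)C)cc3)ccc2n1`, 22 nM
compound 2, `CCCc1cc(N)c2cc(NC(=O)/C=C/c3ccc(N)cc3)ccc2n1`, 190 nM

Going by the values given here, in an assay on isolated protein for displacement of a labelled ligand from melanin-concentrating hormone receptor 1 (Homo sapiens) (a lower number here means a stronger inhibitor, a higher number a weaker inhibitor), compound 2 stands at the highest of the two numbers, and the only measured step in the set leads to it: an 8.6-fold higher number from compound 1 to compound 2 (0.94 log units; beyond the scatter). Compound 2 thus binds less strongly than compound 1, and the difference lies beyond the scatter.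

Compound 3, `CCCc1cc(N)c2cc(NC(=O)/C=C/c3ccc(F)cc3)ccc2n1`, differs from compound 2 by fluoro in place of amino on an aromatic carbon. Among the compounds with values here, the only step that bears on this change is the one from compound 1 to compound 2, since both changes touch the same position on the same ring. That step was modest in size and ran toward a weaker inhibitor when amino entered; the reverse move, amino leaving, is therefore expected to run the other way, though fluoro is neither tert-butyl nor amino, so the full reverse is not assumed. Compound 3 is expected to show a 3.8-fold lower number from compound 2 to compound 3 (0.58 log units; beyond the scatter). The estimate for compound 3 in this assay is 50 nM, with a range from 15 nM to 160 nM.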

Compound 3, half-maximal inhibitory concentration: 130 nM
Compound 3: middle estimate off by 2.6-fold (0.41 log units), on the low side; measured number inside the range.
By their numbers in this assay, from the lowest: compound 1; then compounds 3 and 2 (each within the scatter of the next).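

In this assay, fluoro in place of amino, on an aromatic carbon para to a large group, gives a 1.5-fold lower number from compound 2 to compound 3 (0.16 log units; within the scatter), so this assay does not separate the two groups, although amino counts one hydrogen-bond donor and one acceptor and fluoro counts neither. Tert-butyl stands apart from both: a 5.9-fold higher number from compound 1 to compound 3 (0.77 log units; beyond the scatter) joins the earlier 8.6-fold higher number from compound 1 to compound 2 (0.94 log units; beyond the scatter), and both steps lie beyond the scatter, so compound 1 remains the strongest inhibitor of the three, and the earlier drop with amino now appears with fluoro too. No measurement at hand offers an explanation for this pattern.

The compounds shown leave open how other groups at this position would read, such as isopropyl, methoxy, chloro or trifluoromethyl, and so which feature of tert-butyl goes with its lower number. They also leave open whether the same order among these groups would hold if the propyl chain on the shared core gave way to an ethyl chain, or its amino group to a methylamino group.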